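A few compounds are considered here, and "the series" means these few. Any claim that something is new, unique, unknown or untested is made for them only; others in the source may bear on it.

The study concerns a small set of compounds that share one core and were examined in a physicochemical assay for solubility, at pH 6.5; a lower number here means a less soluble compound, a higher number a more soluble compound. Compound 1, `CS(=O)(=O)c1cccc(-c2ccc3ncc(-c4ccc(S(=O)(=O)N5CCNCC5)cc4)n3n2)c1`, gives in this assay a value of 162000 nM. Compound 3, `CS(=O)(=O)c1ccc(-c2cnc3ccc(-c4cncc(N)c4)nn23)cc1`, gives in this assay a value of 15000 nM. Compound 2, `NC(=O)c1ccc(-c2cnc3ccc(-c4cccc(S(=O)(=O)C5CC5)c4)nn23)cc1`, stands apart: in this assay compound 2 gives only < 5000 nM, which is a limit of the assay and not a number. This is the limit of < 5000 nM in this assay, at which 1 of the 3 values shown sits, so compound 2 is known only to sit at the lower edge of what the assay reports, without a figure of its own.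

The step followed here leads from compound 2 to compound 4, `O=S(=O)(c1cccc(-c2ccc3ncc(-c4ccc(-c5nnn[nH]5)cc4)n3n2)c1)C1CC1`, which has not yet been measured in this assay. The change is 1H-tetrazol-5-yl in place of carbamoyl on an aromatic carbon. Within the data shown here, no pair of measured compounds differing in one place exists in this set, so the size of such a step has no measured counterpart to lean on. Even so, the solubility of compound 4 is expected to move upward out of the limit and into the range where a number is returned, and the estimate means a step of an at least 4.0-fold higher number from compound 2 to compound 4 (0.60 log units; beyond the scatter). For compound 4 the expected value in this assay is 20000 nM, with a range from 4000 nM to 100000 nM.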

Compound 4, solubility: 183000 nM
Compound 4: middle estimate off by 9.2-fold (0.96 log units), on the low side; the measured number lies above the stated range.
By their numbers in this assay, from the lowest: compound 3; then compounds 1 and 4 (each within the scatter of the next). At a limit, below all of these: compound 2.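

In this assay, the set now holds its first pair of compounds that differ in one place, and the step reads as an at least 36-fold higher number from compound 2 to compound 4 (1.56 log units; beyond the scatter). Compound 2 stands at a limit of the assay and not at a number, and the printed step therefore gives only the least possible size of the change: the limit of < 5000 nM in this assay, at which 1 of the 4 values shown sits. Compound 4 returns a number, 183000 nM, which shows that at this place, on an aromatic carbon para to a large group, the exchange of carbamoyl for 1H-tetrazol-5-yl takes the read-out off the lower edge of what the assay reports, though this rests on one pair alone.

The compounds shown leave open whether another group at this same place, such as a carboxylic acid or a primary amine, would give a number like that of compound 4. Among these compounds, they also leave open whether the step holds with other groups elsewhere on the shared core, as compound 1 and compound 3 each differ from compound 4 in more than one place and offer no second pair.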